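Solubility at low pH: swapping the lactam for an imidazole

A few compounds are considered here, and "the series" means these few. Any claim that something is new, unique, unknown or untested is made for them only; others in the source may bear on it.

Compound 1 `CC(C)C(c1ccc(-c2ccc3cccc(F)c3c2)[nH]c1=O)N1CCCCC1=O` is the reference for this step. In a physicochemical assay for solubility, measured as kinetic solubility, at pH 2 (a lower number here means a less soluble compound, a higher number a more soluble compound), compound 1 gives 23500 nM, the lowest of the three numbers in hand, though every gap to the others is within the scatter. Compound 3 `CC(C)[C@@H](C[C@H]1CCNC1=O)c1ccc(-c2ccc3cccc(F)c3c2)[nH]c1=O` gives 25400 nM in this assay, and compound 2 `CCn1ncc2c(F)cc(-c3ccc(C(CC)(CC)c4nnc(C)[nH]4)c(=O)[nH]3)cc21`, built on a different core, gives 33900 nM. No pair among these three differs in only one place, so no single-change step can be read from them, and the three values together say only that the series so far sits in one narrow band.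

Compound 4 `Cc1c[nH]c(C(c2ccc(-c3ccc4cccc(F)c4c3)[nH]c2=O)C(C)C)n1` is not yet measured. It differs from compound 1 as follows: 4-methyl-1H-imidazol-2-yl in place of 2-oxopiperidin-1-yl on a saturated chain carbon bound to an aromatic carbon and a saturated chain carbon. Within the data shown here, with no measured step of this kind to lean on, the expectation for compound 4 is an increase in this assay of modest size, a step from compound 1 to compound 4 of a 2.1-fold higher number from compound 1 to compound 4 (0.33 log units; beyond the scatter), which may or may not clear the scatter. The estimate for compound 4 in this assay is 50000 nM, with a range from 15000 nM to 150000 nM.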

Compound 4, solubility: 6300 nM
Compound 4: the middle estimate sits 7.9-fold (0.90 log units) above what was measured; measured number outside the range, below it.
By their numbers in this assay, from the lowest: compound 4; then compounds 1, 3 and 2 (each within the scatter of the next).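

Among these compounds, at the saturated chain carbon bound to an aromatic carbon and a saturated chain carbon, 4-methyl-1H-imidazol-2-yl in place of 2-oxopiperidin-1-yl gives the first single-place step in this assay, with a 3.7-fold lower number from compound 1 to compound 4 (0.57 log units; beyond the scatter), so the number in this assay does depend on the group at this position. The change alters several features at once, replacing a six-membered non-aromatic ring with a five-membered aromatic ring and adding a hydrogen-bond donor, so the step cannot be assigned to any one of them. No measurement on hand accounts for the step.

On these data alone, it remains open whether the step belongs to the imidazole ring itself or to its methyl group. A primary amine or a carboxylic acid at this position, and the same swap on the core of compound 2, would remain to be compared.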